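The source may report more compounds than this note shows. Statements on the series, on what has been measured and on what is new or still open speak of the compounds shown alone.

Measured compounds and their values in a functional assay on the whole organism for inhibition, with Brassica rapa subsp. chinensis as the target, with a stated time of 3 days, tested at 100 ppm; on this read-out higher numbers stand for more inhibition of growth at the one concentration tested and lower numbers for less inhibition of growth:

Compound 1 `CC(C)=CCCC(C)CCOC(=O)/C=C/c1ccc(C(C)C)cc1` gives 0%.
Compound 2 `COC(=O)/C=C/c1ccc(C(C)C)cc1` gives 21%.

Of the two numbers in this assay, compound 2 stands highest; its nearest neighbour is compound 1, whose number lies lower by a margin beyond the usual scatter. Compound 3 `CCOC(=O)/C=C/c1ccc(C(C)C)cc1` is the next compound. Compared with compound 2 it carries methyl in place of hydrogen on a saturated chain carbon bound to an oxygen next to a carbonyl group. Going by the values given here, no pair of measured compounds differs by this kind of change, so there is no measured step to lean on; the expectation rests on the value of compound 2 alone. A change of this small size, at the ester end of the shared core, is expected to move the number little, in no particular direction. The expected step is a number 1 percentage points lower from compound 2 to compound 3 (within the scatter), within the usual scatter. For compound 3 the estimate is 20%, with a plausible range from 5% to 40%.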

Compound 3, percent growth inhibition at one concentration: 0%
The estimate for compound 3 lay 20 percentage points above the measured number; measured number below the stated range.
By their numbers in this assay, from the lowest: compounds 1 and 3 (each within the scatter of the next); then compound 2.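

In this assay the ester end of the shared core turns out to respond to even the smallest edit: methyl in place of hydrogen on a saturated chain carbon bound to an oxygen gives a number 21 percentage points lower from compound 2 to compound 3 (beyond the scatter) and so removes the growth inhibition seen with the methyl ester. Setting the ethyl ester against the ester carrying the 1,5-dimethylhex-4-en-1-yl group gives no change at the digits printed from compound 1 to compound 3 (within the scatter), so among these three esters only compound 2 stands apart. Nothing available explains why one added methyl has this effect.

The compounds shown leave open whether the inhibition needs the ester at all, since a carboxylic acid or an amide at this end could keep or lose it. They also leave open how a propyl ester or a branched isopropyl ester would read.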